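This account rests on a few compounds, and the source may have more. Where it says the series, first, only, none or still open, it means among the compounds named here.

Compound 1 `CC(C)(C)c1cc(NC(=O)[C@@H]2CCCCN2Cc2ccc(Cl)cc2)no1` in an ADME assay (liver) for metabolic stability, with Liver microsome (Homo sapiens) as the target, read by LC-MS, using microsomes and NADPH, tested at 1 uM (a lower number here means that the compound disappears faster, a higher number that the compound lasts longer), gives 0.15 h.
Compound 2 `CC(C)(C)c1cc(NC(=O)[C@@H]2CCCCN2C(=O)C2CCS(=O)(=O)CC2)no1` in this assay gives > 2 h, which is a limit of the assay and not a number.

Compound 2 therefore stands at the limit of > 2 h in this assay, at which 1 of the 2 values shown sits; how far beyond that limit its half-life lies is not known. Compound 3 `CC(C)(C)c1cc(NC(=O)[C@@H]2CCCCN2C(=O)CC2CCOCC2)no1` differs from compound 2 in one place: (oxan-4-yl)methyl in place of 1,1-dioxothian-4-yl on a carbonyl carbon. For the measured compounds named here, no step between two measured compounds covers this change, so nothing measured tells how it shifts the half-life. Going by the values given here, the two measured values show only that compound 1 disappears quickly, while compound 2 is reported as a limit. For compound 3 a modest step downward from compound 2 is expected, roughly an at least 1.6-fold lower number from compound 2 to compound 3 (0.22 log units; that floor lies within the scatter), and this estimate rests on compound 2 standing at the limit of > 2 h in this assay, at which 1 of the 2 values shown sits. Compound 3 is expected to give about 1.2 h in this assay, with a range from 0.4 h to 3 h.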

Compound 3, half-life: 1.83 h
For compound 3 the middle estimate is 1.5-fold (0.18 log units) below the measured one; measured number inside the range.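

Replacing 4-chlorobenzyl with ((oxan-4-yl)methyl)carbonyl on the amine nitrogen in a ring of the shared core gives a 12-fold higher number from compound 1 to compound 3 (1.09 log units; beyond the scatter) in this assay. Compound 3 thus shows that a long half-life in this series does not require the 1,1-dioxothian-4-yl group, as its (oxan-4-yl)methyl replacement on the carbonyl carbon also provides one. That replacement gives an at least 1.0-fold lower number from compound 2 to compound 3 (0.03 log units; that floor lies within the scatter), but this is only a floor and the true size of the step is unknown because compound 2 carries a limit of the assay and not a number: the limit of > 2 h in this assay, at which 1 of the 3 values shown sits.

Going by these compounds, the step from compound 1 changes the linking carbonyl and the ring-bearing group together, so their separate shares remain unknown. A 4-chlorobenzoyl group on the same nitrogen would help separate them, while a carboxylic acid on the carbonyl-bearing chain remains an open case.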